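The compounds below may be only part of what the source reports. "The series", "measured", "known", "first", "only" and "open" are said of these compounds alone.

Three compounds have been measured in a functional assay on KB cells (Homo sapiens) for inhibition; on this read-out lower numbers stand for stronger inhibition and higher numbers for weaker inhibition:

Compound 1, `Cc1ccc(Cn2c(Cl)nc3cc(Cl)c(Cl)cc32)cc1`, gives > 100000 nM, which is a limit of the assay.
Compound 2, `FC(F)(F)c1ccc(Cn2c(Cl)nc3cc(Cl)c(Cl)cc32)cc1`, gives > 100000 nM, again a limit of the assay.
Compound 3, `Cc1cccc(Cn2c(Cl)nc3cc(Cl)c(Cl)cc32)c1`, gives > 100000 nM, also a limit of the assay.

Compound 1 and compound 2 differ by trifluoromethyl in place of methyl on an aromatic carbon. Because (the limit of > 100000 nM in this assay, at which 3 of the 3 values shown sit), the step that the two limits leave unreadable from compound 1 to compound 2 cannot be read in this assay. Compound 3 has the same atoms as compound 1, joined differently, and the difference between the two cores is not broken down here.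

The unmeasured compound 4, `FC(F)(F)c1cccc(Cn2c(Cl)nc3cc(Cl)c(Cl)cc32)c1`, stands to compound 3 as compound 2 stands to compound 1, differing by trifluoromethyl in place of methyl on an aromatic carbon. This is the same kind of change, though not the same change: in compound 2 the entering group sits para to a large group, whereas in compound 4 it sits meta to a large group.

Since the change from compound 1 to compound 2 left the reading at a limit, and compound 3 itself sits at that limit, compound 4 is expected to remain there as well. The step that the limit leaves unreadable from compound 3 to compound 4 is thus expected to be essentially nil. Compound 4 is estimated at 150000 nM in this assay, with the expectation that the assay will most likely report only a limit.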

Compound 4, half-maximal inhibitory concentration: > 100000 nM
Compound 4 gave a limit, no number; the forecaster's own chance of this, stated with the estimate: 90%; the middle value is on the limit's open side.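

No new step can be read between compound 3 and compound 4 in this assay, because the change from methyl to trifluoromethyl leaves both compounds at a limit of the assay: the limit of > 100000 nM in this assay, at which 4 of the 4 values shown sit.

The compounds shown leave open how far each of them lies beyond that limit, how they rank against one another, and whether any compound on the shared core would give a readable value in this assay.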